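Sulfonamide to Amide at the Ring Nitrogen of Compound 1

This account rests on a few compounds, and the source may have more. Where it says the series, first, only, none or still open, it means among the compounds named here.

Compound 1 `COc1cc(N(Cc2nc3ccccc3[nH]2)S(=O)(=O)c2ccc(F)cc2)cc(OC)c1OC` gives 5680 nM in a functional assay on MGC-803 cells (Homo sapiens) for inhibition, read by MTT assay, with a stated time of 48 h (a lower number here means a stronger inhibitor, a higher number a weaker inhibitor), the lowest of the two numbers measured; compound 2 `COc1ccc(S(=O)(=O)N(Cc2nc3ccccc3[nH]2)c2cc(OC)c(OC)c(OC)c2)cc1OC` gives 22500 nM, and the step of a 4.0-fold higher number from compound 1 to compound 2 (0.60 log units; beyond the scatter) alters only the aryl on the sulfonyl sulfur. Compound 3 `COc1cc(N(Cc2nc3ccccc3[nH]2)C(=O)c2ccc(C)cc2)cc(OC)c1OC` differs from compound 1 by (4-methylphenyl)carbonyl in place of (4-fluorophenyl)sulfonyl on a nitrogen on an aromatic ring. No measured step touches the sulfonyl group itself, so nothing shown bears directly on this change, and no step beyond the scatter is expected. Compound 3 is therefore estimated at 6000 nM (range 2000 nM to 20000 nM), an expected step of a 1.1-fold higher number from compound 1 to compound 3 (0.02 log units; within the scatter).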

Compound 3, half-maximal inhibitory concentration: 30500 nM
Compound 3: the middle estimate sits 5.1-fold (0.71 log units) below what was measured; the whole stated range lies below it.
By their numbers in this assay, from the lowest: compound 1; then compounds 2 and 3 (each within the scatter of the next).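

In this assay the group on the nitrogen matters as well as the aryl on the sulfonyl sulfur: with (4-methylphenyl)carbonyl in place of (4-fluorophenyl)sulfonyl, the result is a 5.4-fold higher number from compound 1 to compound 3 (0.73 log units; beyond the scatter) and inhibition is weaker. This single step swaps both the linking unit and the ring substituent, so their contributions cannot be separated. No evidence given here accounts for the loss. On these data alone, how (4-fluorophenyl)carbonyl or (4-methylphenyl)sulfonyl would behave remains open, and so does any result for methylsulfonyl on this nitrogen.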